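Piperidine nitrogen substitution and maximal cAMP response

This account rests on a few compounds, and the source may have more. Where it says the series, first, only, none or still open, it means among the compounds named here.

Of the compounds shown here, two have been measured in a functional assay on isolated protein for agonist activity at Glucose-dependent insulinotropic receptor (Homo sapiens), read by HTRF and cAMP accumulation (a lower number here means a smaller maximal response, a higher number a larger maximal response), so far. Compound 1 `CC(C)OC(=O)N1CCC(O[C@H]2CC[C@H](Oc3ccc(S(C)(=O)=O)nc3)CC2)CC1` carries an isopropoxycarbonyl on the piperidine nitrogen and gives 101% in this assay. Compound 2 `CS(=O)(=O)c1cnc(O[C@H]2CC[C@H](OC3CCN(C(=O)Oc4ccccc4)CC3)CC2)cn1` carries a phenoxycarbonyl at the same nitrogen and gives 116% in this assay. Compound 2 thus stands at the higher of the two values, and its gap to compound 1 lies beyond the usual scatter of the assay.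

Compound 3 `CC(C)c1noc(CN2CCC(O[C@H]3CC[C@H](Oc4cnc(S(C)(=O)=O)cn4)CC3)CC2)n1` is the next compound, not yet measured. It differs from compound 2 in one place: (3-isopropyl-1,2,4-oxadiazol-5-yl)methyl in place of phenoxycarbonyl on an amine nitrogen in a ring

Among the measured compounds shown here, no measured pair shows this kind of change, so its effect is unknown. Both measured compounds reach a full or above-full maximal response, so a maximal response near the reference is expected for compound 3 as well, most likely with a moderate decrease from compound 2 that may not exceed the scatter; this is worded as an expectation only. The expected step is a number 14 percentage points lower from compound 2 to compound 3 (beyond the scatter) in this assay. Compound 3 is accordingly estimated at 102% in this assay, within a range of 80% to 120%.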

Compound 3, largest response reached (Emax), in percent of the reference or control that the assay uses: 102%
Beside the measured number, compound 3's estimate shows no gap at the digits printed; measured number inside the range.
By their numbers in this assay, from the lowest: compounds 1 and 3 (each within the scatter of the next); then compound 2.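

In this assay, the amine nitrogen in the six-membered non-aromatic ring accepts a replacement of phenoxycarbonyl by (3-isopropyl-1,2,4-oxadiazol-5-yl)methyl with a measurable cost, a number 14 percentage points lower from compound 2 to compound 3 (beyond the scatter), even though both groups count the same number of heavy atoms. The carbonyl on this nitrogen, present in both earlier compounds, is therefore not needed for a full response: compound 3 still gives 102% with a five-membered aromatic ring with 3 hetero atoms at this place, so the position is open to more than one type of substituent. No measurement on these compounds speaks to what lies behind the size of this step.

The change replaces the carbonyl, the six-membered aromatic ring and the attachment to the nitrogen in a single step, and the compounds shown do not tell which of these parts carries the difference. A benzyl group on the same nitrogen would separate the methylene attachment from the ring change, while a tert-butoxycarbonyl group would show how far the response follows the group on the carbonyl oxygen.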